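Adding a third methoxy to the aryl ketone of compound 3

This account rests on a few compounds, and the source may have more. Where it says the series, first, only, none or still open, it means among the compounds named here.

Three compounds share a pyrazole-linked enone core. Compound 1 `COc1cc(-c2cc(/C=C/C(=O)c3ccc(Cl)c(Cl)c3)[nH]n2)cc(OC)c1OC` gives 67% in a functional assay on NCI-H226 cells (Homo sapiens) for cytotoxicity, read by sulforhodamine B assay, with a stated time of 48 h, tested at 10 uM; on this read-out lower numbers stand for a stronger effect and higher numbers for a weaker effect at the one concentration tested. Compound 2 `COc1ccc(-c2cc(/C=C/C(=O)c3cc(OC)c(OC)c(OC)c3)[nH]n2)cc1OC` gives -8% in this assay. Compound 3 `COc1ccc(C(=O)/C=C/c2cc(-c3cc(OC)c(OC)c(OC)c3)n[nH]2)cc1OC` gives -81% in this assay, the lowest of the three numbers; compound 2 is nearest and compound 1 furthest, both beyond the scatter. Going by the values given here, the one single-point step is a number 148 percentage points lower from compound 1 to compound 3 (beyond the scatter), a large fall.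

Compound 4 `COc1cc(C(=O)/C=C/c2cc(-c3cc(OC)c(OC)c(OC)c3)n[nH]2)cc(OC)c1OC` differs from compound 3 only in this way: methoxy in place of hydrogen on an aromatic carbon. Among the compounds with values here, no measured step changes this position, so the step from compound 1 to compound 3 bears on it only indirectly, showing that the carbonyl-side ring matters greatly for this assay. Compound 2 carries the same trimethoxy ketone ring as compound 4 but a different pyrazole-side ring, so its value is only loosely informative.

Compound 4 is therefore expected to remain strongly active, with an estimated step of a number 21 percentage points higher from compound 3 to compound 4 (beyond the scatter) from compound 3, giving an estimate of -60% with a range of -105% to 5% in this assay.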

Compound 4, a percentage reported as activity, at one concentration (the size of the read-out at that concentration, not a potency): -92%
Estimate against measurement, compound 4: 32 percentage points above, and the stated range covers the measured number.
By their numbers in this assay, from the lowest: compound 4; then compound 3; then compound 2; then compound 1.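

The methoxy in place of hydrogen on the carbonyl-side ring moves the number in this assay only modestly (a number 11 percentage points lower from compound 3 to compound 4 (beyond the scatter)), so this position accepts a third methoxy and the effect grows slightly from an already low number. The same kind of change on the pyrazole-side ring counts for far more (a number 84 percentage points lower from compound 2 to compound 4 (beyond the scatter)), so in these compounds the added methoxy matters much more on that ring than on the carbonyl-side ring. Nothing at hand accounts for either step.

On these data alone, it remains open whether an amine, a hydroxyl or a longer alkoxy chain at this position would hold the number as low as methoxy does. The compounds shown also leave open whether hydrogen and methoxy differ here by the same amount with another group on the pyrazole-side ring.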